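A few compounds are considered here, and "the series" means these few. Any claim that something is new, unique, unknown or untested is made for them only; others in the source may bear on it.

Measured so far in a functional assay on MDA-MB-231 cells (Homo sapiens) for antiproliferative activity, read by MTT assay, with a stated time of 24 h; a lower number here means a stronger inhibitor, a higher number a weaker inhibitor:
- compound 1 `CCCCc1oc2ccccc2c1C(=O)c1ccc(OCCCC(=O)N2CCCCC2)cc1`: 36000 nM
- compound 2 `CCCCc1oc2ccccc2c1C(=O)c1ccc(OCCCC(=O)N2CCOCC2)cc1`: 31600 nM
- compound 3 `CCCCc1oc2ccccc2c1C(=O)c1ccc(OCCCC(=O)N(C)Cc2ccccc2)cc1`: > 50000 nM (a limit, not a number)

Compound 3 has no exact value in this assay. It stands at the limit of > 50000 nM in this assay, at which 1 of the 3 values shown sits.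

The next compound, compound 4 `CCCCc1oc2ccccc2c1C(=O)c1ccc(OCCCC(=O)N[C@H](C)c2ccccc2)cc1`, has the same atoms as compound 3, joined differently: (1-phenylethyl)amino in place of benzyl(methyl)amino on a carbonyl carbon. On a carbonyl carbon, (1-phenylethyl)amino stands in place of benzyl(methyl)amino. Among the compounds with values here, the amide of compound 4 therefore keeps an amide hydrogen and gains a defined stereocentre, and no measured compound offers this kind of change directly.

The nearest evidence comes from the other swaps of the group on that carbonyl carbon. These are a 1.1-fold lower number from compound 1 to compound 2 (0.06 log units; within the scatter), an at least 1.3-fold higher number from compound 1 to compound 3 (0.14 log units; that floor lies within the scatter) and an at least 1.5-fold higher number from compound 2 to compound 3 (0.19 log units; that floor lies within the scatter). Each lies within the scatter, although the last two are only floors set by a limit. Three compounds are a thin basis, but they give no reason to expect a large move in either direction. No step beyond the scatter is therefore expected, and compound 4 may also return only a limit.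

The estimated step is an at least 1.2-fold lower number from compound 3 to compound 4 (0.09 log units; that floor lies within the scatter). For compound 4 the expected value is 40000 nM, with an estimated range from 18000 nM to 70000 nM.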

Compound 4, half-maximal inhibitory concentration: > 50000 nM
Compound 4 was reported as a limit; the forecaster's own chance of this, stated with the estimate: 45%; middle value at least 1.2-fold (0.09 log units) away from the limit.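

In this assay, compound 4 gives only a limit, > 50000 nM, not a number, so an amide that keeps its amide hydrogen and carries a defined stereocentre does not bring a readable value at this carbonyl carbon. With limits at both ends, the step between compound 3 and compound 4 cannot be read, and the comparisons with the other two amides give an at least 1.5-fold higher number from compound 2 to compound 4 (0.19 log units; that floor lies within the scatter) and an at least 1.3-fold higher number from compound 1 to compound 4 (0.14 log units; that floor lies within the scatter), both only floors, so the amide hydrogen has not been shown to matter here. Compound 3 and compound 4, the two whose group on the carbonyl carbon holds an aromatic ring, now share the limit while compound 1 and compound 2 have numbers, although no step behind that split is shown to lie beyond the scatter: the limit of > 50000 nM in this assay, at which 2 of the 4 values shown sit.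

On these data alone, the mirror-image form of the (1-phenylethyl)amino group and a plain benzylamino group, which has the amide hydrogen without the branching methyl, remain open. So does whether a carboxylic acid in place of the amide, or a longer chain leading to the carbonyl, could move the number far beyond the scatter in either direction.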